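Replacing Ethylsulfonyl with Naphthalenyl in a Receptor Antagonist Series

The source may hold more compounds than are shown below. What is called first, only, known or untested is meant among the compounds shown, and "the series" means these compounds.

Compound 3 `CCS(=O)(=O)c1ccccc1Cc1c2c(n(CC(=O)O)c1C)CCNC2=O` gives 550 nM in a functional assay on CHO.K1 cells for antagonist activity at prostaglandin D2 receptor 2 (Homo sapiens), read by GTPgammaS binding, with a stated time of 1 h (on this read-out lower numbers stand for stronger inhibition and higher numbers for weaker inhibition), the highest of the three numbers measured. Compound 1 `COc1cccc(S(=O)(=O)c2ccccc2Cc2c3c(n(CC(=O)O)c2C)CCNC3=O)c1` gives 12 nM and compound 2 `Cc1c(Cc2ccccc2S(=O)(=O)c2ccc(Cl)cc2)c2c(n1CC(=O)O)CCNC2=O` gives 8.5 nM in this assay. The change to compound 4 `Cc1c(Cc2ccccc2-c2cccc3ccccc23)c2c(n1CC(=O)O)CCNC2=O` is naphthalen-1-yl in place of ethylsulfonyl on an aromatic carbon, sitting on an aromatic carbon of a six-membered aromatic ring of carbon only, ortho to a large group. Among the measured compounds shown here, the steps that bear on it are a 46-fold higher number from compound 1 to compound 3 (1.66 log units; beyond the scatter) and a 65-fold higher number from compound 2 to compound 3 (1.81 log units; beyond the scatter), both large, so an aromatic ring in this position went with far lower numbers than ethyl. Compound 4 carries two fused aromatic rings but no sulfonyl, a combination not tested here, so a drop beyond the scatter is expected but smaller than those steps. For compound 4 the estimate is 40 nM, ranging from 8 nM to 200 nM, an expected step of a 14-fold lower number from compound 3 to compound 4 (1.14 log units; beyond the scatter).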

Compound 4, half-maximal inhibitory concentration: 480 nM
Beside the measured number, compound 4's estimate is 12-fold (1.08 log units) below it; measured number above the stated range.
By their numbers in this assay, from the lowest: compounds 2 and 1 (each within the scatter of the next); then compounds 4 and 3 (each within the scatter of the next).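

Replacing ethylsulfonyl with naphthalen-1-yl gives a 1.1-fold lower number from compound 3 to compound 4 (0.06 log units; within the scatter), so an aromatic ring system on this carbon without a sulfonyl does not separate from ethylsulfonyl. The aryl sulfonyl compounds stay well apart, with a 56-fold higher number from compound 2 to compound 4 (1.75 log units; beyond the scatter) and a 40-fold higher number from compound 1 to compound 4 (1.60 log units; beyond the scatter), and in these four compounds the low numbers appear only where sulfonyl and aromatic ring occur together, in compound 1 and compound 2. No measurement given here explains this. Still open, from the compounds shown here alone, is whether a carbonyl or an ether oxygen carrying a phenyl in place of the sulfonyl would keep those low numbers.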